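A Chloro-for-Methyl Swap at an Inactive Limit

The compounds below may be only part of what the source reports. "The series", "measured", "known", "first", "only" and "open" are said of these compounds alone.

Compound 1 `Cc1ccc(Cn2cc(COc3ccc4c(=O)ccoc4c3)nn2)cc1` was examined in a functional assay on SGC-7901 cells (Homo sapiens) for cytotoxicity, read by MTT assay, with a stated time of 48 h; on this read-out lower numbers stand for stronger inhibition and higher numbers for weaker inhibition. Compound 1 gives > 100000 nM, which is a limit of the assay rather than a measured number. Its two measured neighbours stand no differently. Compound 2 `O=c1ccoc2cc(OCc3cn(Cc4cccc(F)c4)nn3)ccc12` gives > 100000 nM, again a limit. Compound 3 `CC(C)(C)c1ccc(Cn2cc(COc3ccc4c(=O)ccoc4c3)nn2)cc1` gives > 100000 nM, also a limit. The step that the two limits leave unreadable from compound 1 to compound 2 therefore cannot be sized, and neither can a step that the two limits leave unreadable from compound 1 to compound 3; both are fixed by the limit of > 100000 nM in this assay, at which 3 of the 3 values shown sit.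

Compound 4 `O=c1ccoc2cc(OCc3cn(Cc4ccc(Cl)cc4)nn3)ccc12` differs from compound 1 in one place: chloro in place of methyl on an aromatic carbon. This change sits on the same six-membered aromatic ring of carbon only where the 3-fluorophenyl in place of 4-methylphenyl and the tert-butyl in place of methyl exchanges each left the read-out at the limit. With no readable step among the measured compounds, no movement beyond the scatter can be anticipated in this assay. Compound 4 is therefore expected to remain at the limit, a step that the limit leaves unreadable from compound 1 to compound 4. Compound 4 is estimated at 150000 nM, within a range from 50000 nM to 500000 nM.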

Compound 4, half-maximal inhibitory concentration: > 100000 nM
Compound 4 gave a limit, no number; the forecaster's own chance of this, stated with the estimate: 80%; the middle value does not contradict the limit.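

In this assay compound 4 gives > 100000 nM as a limit, not a number. For the compounds shown here, no step between compound 4 and compound 1, compound 2 or compound 3 can be read: the limit of > 100000 nM in this assay, at which 4 of the 4 values shown sit. The compounds shown leave open whether any change on the six-membered aromatic ring of carbon only would give a measured number.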